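Swapping an aryl group on a triazole in a cytotoxicity series

This account rests on a few compounds, and the source may have more. Where it says the series, first, only, none or still open, it means among the compounds named here.

Measured compounds:
- compound 1, `C=C1C[C@]23C[C@@]1(O)CC[C@H]2c1cc(Br)c(O)c(C)c1[C@@H]3Cn1cc(-c2ccc(OC)cc2)nn1`: > 20000 nM
- compound 2, `C=C1C(=O)[C@]23C[C@@]1(O)CC[C@H]2c1ccc(O)c(C)c1[C@@H]3Cn1cc(-c2ccc(C)cc2)nn1`: 830 nM

Both compounds share one core and were tested in a functional assay on HL-60 cells (Homo sapiens) for cytotoxicity, read by MTT assay, with a stated time of 4 days; a lower number here means a stronger inhibitor, a higher number a weaker inhibitor. For compound 1 the value > 20000 nM is a limit of the assay rather than a number. Compound 2 gives 830 nM in this assay; it differs from compound 1 in several places at once, so the two values are only shown side by side, with no single step between them. Compound 1 therefore stands at the weak end of what is shown, at the limit itself (the limit of > 20000 nM in this assay, at which 1 of the 2 values shown sits).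

The unmeasured compound 3, `C=C1C[C@]23C[C@@]1(O)CC[C@H]2c1cc(Br)c(O)c(C)c1[C@@H]3Cn1cc(-c2ccccn2)nn1`, is reached from compound 1 by a single change: pyridin-2-yl in place of 4-methoxyphenyl on an aromatic carbon. Among the compounds with values here, because compound 1 sits at the limit (the limit of > 20000 nM in this assay, at which 1 of the 2 values shown sits), no measured step tells how this assay responds to such a change. The expectation for the step that the limit leaves unreadable from compound 1 to compound 3 is therefore that it stays within the scatter, with no clear gain in potency. Compound 3 is expected to give about 25000 nM, with a likely range from 5000 nM to 100000 nM, and a fair chance that only a limit is reported again.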

Compound 3, half-maximal inhibitory concentration: > 20000 nM
Compound 3: a limit, no number; the forecaster's own chance of this, stated with the estimate: 70%; the middle value is on the limit's open side.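

In this assay compound 3 gives > 20000 nM, which is a limit and not a number. No size can be read for the step between compound 1 and compound 3, because both sit at the same limit: the limit of > 20000 nM in this assay, at which 2 of the 3 values shown sit.

The compounds shown leave open whether pyridin-2-yl in place of 4-methoxyphenyl changes potency at all when the starting compound gives a readable number.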